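Bromo in place of benzoyl on the shared core

The source may report more compounds than this note shows. Statements on the series, on what has been measured and on what is new or still open speak of the compounds shown alone.

Compound 1 `O=C(c1ccccc1)c1ccc2c(c1)oc(=O)n2C(=O)NCCCCc1ccccc1` gives the lowest of the two numbers in an assay on HEK293 cells for inhibition of acid ceramidase (Homo sapiens), with a stated time of 10 min (a lower number here means a stronger inhibitor, a higher number a weaker inhibitor), at 29 nM. Compound 2 `O=C(NCCCCc1ccc2ccccc2c1)n1c(=O)oc2ccccc21` gives 71 nM in this assay, a gap beyond the usual scatter. Compound 3 `O=C(NCCCCc1ccccc1)n1c(=O)oc2cc(Br)ccc21` differs from compound 1 by bromo in place of benzoyl on an aromatic carbon. Among the measured compounds shown here, no measured pair shows this change, so the step is uncertain; a modest loss of potency, beyond the scatter, is expected rather than a gain. Compound 3 is therefore estimated at 65 nM in this assay, between 20 nM and 220 nM, a step from compound 1 to compound 3 of a 2.2-fold higher number from compound 1 to compound 3 (0.35 log units; beyond the scatter).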

Compound 3, half-maximal inhibitory concentration: 31 nM
Compound 3: middle estimate off by 2.1-fold (0.32 log units), on the high side, within the range that was stated.
By their numbers in this assay, from the lowest: compounds 1 and 3 (each within the scatter of the next); then compound 2.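

Bromo in place of benzoyl on this aromatic carbon gives a 1.1-fold higher number from compound 1 to compound 3 (0.03 log units; within the scatter) in this assay and so costs nothing that can be told from the scatter. In this pair, then, the benzoyl group with its six-membered aromatic ring and carbonyl is not required to keep the number at this level. No measurement shown here explains why the two groups read alike.

Going by these compounds, it remains open whether a methoxy group, an amine or a carboxylic acid on this carbon would hold the same level. On these data alone, it is also open whether the swap would read the same with a longer chain on the shared core.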